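The source may hold more compounds than are shown below. What is called first, only, known or untested is meant among the compounds shown, and "the series" means these compounds.

Measured so far:
Compound 1 `CC(Oc1ccccc1-c1ccc([N+](=O)[O-])cc1)C1=NCCN1`; in an assay on CHO cells for displacement of a labelled ligand from Alpha-2C adrenergic receptor (Homo sapiens) (on this read-out lower numbers stand for stronger inhibition and higher numbers for weaker inhibition), compound 1 gives 302 nM.
Compound 2 `CC(Oc1ccccc1-c1ccccc1[N+](=O)[O-])C1=NCCN1`; in this assay compound 2 gives 1230 nM.
Compound 3 `CC(Oc1ccccc1-c1ccccc1O)C1=NCCN1`; in this assay compound 3 gives 1620 nM.

Compound 3 carries the highest number of the three. The step of a 1.3-fold higher number from compound 2 to compound 3 (0.12 log units; within the scatter) lies within the scatter, so compounds 2 and 3 are not separated by it. Compound 1 stands well apart from compound 3, a gap beyond the scatter.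

Compound 4 `CC(Oc1ccccc1-c1ccccn1)C1=NCCN1` differs from compound 3 by pyridin-2-yl in place of 2-hydroxyphenyl on an aromatic carbon. Among the measured compounds shown here, the only measured step that touches the group which leaves is a 1.3-fold higher number from compound 2 to compound 3 (0.12 log units; within the scatter), an exchange of one substituent within that group that left the number essentially unchanged. For the measured compounds named here, no measured step exchanges the whole group for a pyridin-2-yl, so nothing bears directly on the new ring. Compound 2 gives 1230 nM and compound 3 gives 1620 nM, both far from compound 1. On that basis the expectation for compound 4 is a number in their neighbourhood. The expected outcome is a 1.5-fold lower number from compound 3 to compound 4 (0.17 log units; within the scatter), nothing beyond the scatter. The estimate for compound 4 in this assay is 1100 nM, within 350 nM to 3500 nM.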

Compound 4, inhibition constant: 1260 nM
Beside the measured number, compound 4's estimate is 1.1-fold (0.06 log units) below it, within the range that was stated.
By their numbers in this assay, from the lowest: compound 1; then compounds 2, 4 and 3 (each within the scatter of the next).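

In this assay, exchanging the whole 2-hydroxyphenyl for pyridin-2-yl gives a 1.3-fold lower number from compound 3 to compound 4 (0.11 log units; within the scatter), so at this place, ortho to a group of 8 heavy atoms, a change of the entire ring leaves the number as unchanged as the earlier substituent exchange did. The hydrogen-bond donor of 2-hydroxyphenyl is absent from pyridin-2-yl and a ring nitrogen enters, yet compounds 3 and 4 are not separated by this read-out. No supporting data explain why the number holds across this change.

Open, on these data alone, is what sets compound 1 apart at 302 nM, whether the nitro group itself or the place it holds on the ring. Pyridin-4-yl, or an amine or a carboxylic acid in that same place on the phenyl ring, would help separate these two readings.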